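A few compounds are considered here, and "the series" means these few. Any claim that something is new, unique, unknown or untested is made for them only; others in the source may bear on it.

Compound 1 `O=C(/C=C\N(O)c1ccccc1)c1ccc2ccccc2c1` has a free hydroxyl on the nitrogen of its enaminone and in an assay on RBL-1 cells for inhibition of Polyunsaturated fatty acid 5-lipoxygenase (Rattus norvegicus) (a lower number here means a stronger inhibitor, a higher number a weaker inhibitor), compound 1 gives 810 nM. Compound 2 `CN(O)/C=C\C(=O)c1ccc(OCc2ccccc2)cc1` carries a methyl instead of a phenyl on that nitrogen and a benzyloxy-substituted aryl ketone; in this assay compound 2 gives 1900 nM; 1100 nM (2 entries), several entries that sit close together (the several entries of compound 2 in this assay, 1900 nM; 1100 nM (2 entries)). Compound 3 `CC(=O)ON(C)/C=C\C(=O)c1ccc(OCc2ccccc2)cc1` is the acetate of compound 2. For compound 3 this assay reports only a limit, > 25000 nM, so compound 3 stands at the weak end of the values shown, as the one of three that reaches the limit (the limit of > 25000 nM in this assay, at which 1 of the 3 values shown sits). Compound 4 `C/C(=C/N(C)O)C(=O)c1ccc(OCc2ccccc2)cc1` differs from compound 3 by 2-(hydroxy(methyl)amino)-1-methylethenyl in place of 2-(acetoxy(methyl)amino)ethenyl on a carbonyl carbon: the free hydroxyl returns and a methyl is added to the ethenyl chain. Since compound 2, which also carries the free hydroxyl, gives 1900 nM; 1100 nM (2 entries), compound 4 is expected to fall near that level, with an estimate of 1500 nM and a range from 400 nM to 6000 nM. The step from the acetate is therefore expected to be large, toward stronger inhibition, an at least 16-fold lower number from compound 3 to compound 4 (1.22 log units; beyond the scatter).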

Compound 4, half-maximal inhibitory concentration: 8900 nM
Compound 4: middle estimate off by 5.9-fold (0.77 log units), on the low side; measured number above the stated range.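

In this assay, the change on the carbonyl carbon gives an at least 2.8-fold lower number from compound 3 to compound 4 (0.44 log units; beyond the scatter), and the size of this step is bounded by a limit of the assay for compound 3: the limit of > 25000 nM in this assay, at which 1 of the 4 values shown sits. Compound 4 gives 8900 nM, a higher number than any entry of compound 2, which gives 1900 nM; 1100 nM (2 entries). Compound 2 and compound 4 differ only in the methyl on the ethenyl chain, so a free hydroxyl on the nitrogen does not by itself bring a compound to the level of compound 2.

The compounds shown leave open how an ethyl group or a longer chain would read in place of that methyl. They also leave open whether the same methyl would raise the number on the core of compound 1, with its phenyl on the nitrogen.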